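A few compounds are considered here, and "the series" means these few. Any claim that something is new, unique, unknown or untested is made for them only; others in the source may bear on it.

The measured compounds in an ADME assay on RAW264.7 cells (Mus musculus) for cytotoxicity, read by MTT assay, with a stated time of 72 h, tested at 100 uM; on this read-out higher numbers stand for a stronger effect at the one concentration tested and lower numbers for a weaker effect:

compound 1, `O=C(Cn1c(=O)oc2cc(Cl)ccc21)NCc1ccco1`: 50.3%
compound 2, `O=C(Cn1c(=O)oc2cc(Cl)ccc21)Nc1ccccn1`: 43.7%
compound 3, `O=C(Cn1c(=O)oc2cc([N+](=O)[O-])ccc21)NCc1ccccn1`: 33.4%

Compound 3 stands lowest of the three numbers. Its nearest neighbour is compound 2, whose number lies higher by an amount beyond the scatter, and compound 1 lies further above it, also beyond the scatter. Among the compounds with values here, the only step between compounds that differ in one place is a number 6.6 percentage points lower from compound 1 to compound 2 (within the scatter), which concerns the amide-type nitrogen and lies within the scatter.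

The next compound is compound 4, `O=C(Cn1c(=O)oc2cc(Cl)ccc21)NCc1ccccn1`. It differs from compound 3 by chloro in place of nitro on an aromatic carbon. Within the data shown here, no measured step touches this place on the shared core, so the size of this change cannot be read directly from any pair. What can be said is that compound 1 and compound 2, which carry chloro at that place, both give higher numbers than compound 3, though each also differs from compound 3 on the amide-type nitrogen, so the comparison does not rest on one change alone. The expected step of a number 9.6 percentage points higher from compound 3 to compound 4 (within the scatter) is therefore upward and of moderate size, with wide uncertainty. Compound 4 is expected to give about 43%, in a range from 30% to 56%.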

Compound 4, a percentage reported as inhibition, at one concentration (the size of the read-out at that concentration, not a potency): 40%
Compound 4: the middle estimate sits 3 percentage points above what was measured; low and high end bracket the measured number.
By their numbers in this assay, from the lowest: compounds 3, 4, 2 and 1 (each within the scatter of the next, the first and the last beyond it).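

In this assay, the exchange of nitro for chloro on an aromatic carbon of the shared core can now be read as a single change, and a number 6.6 percentage points higher from compound 3 to compound 4 (within the scatter) shows that this exchange does not separate the two groups on this read-out. Within the data shown here, with chloro held in place, (pyridin-2-yl)methyl in place of pyridin-2-yl on the amide-type nitrogen gives a number 3.7 percentage points lower from compound 2 to compound 4 (within the scatter), whereas pyridin-2-yl in place of furan-2-yl on the saturated chain carbon gives a number 10.3 percentage points lower from compound 1 to compound 4 (beyond the scatter), the only single change so far that lies beyond the scatter, and only modestly so. Nothing available on these compounds offers a reason for any of these steps.

On these data alone, only chloro and nitro appear at the aromatic carbon, so it remains open how an amine or a methoxy group there would read, and whether the step from furan-2-yl to pyridin-2-yl would hold with nitro on the core. Each compound also stands at a single concentration, so the numbers tell only of a stronger or weaker effect at that concentration.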